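The source may hold more compounds than are shown below. What is called first, only, known or untested is meant among the compounds shown, and "the series" means these compounds.

Working notes on the series. Two compounds have been run in a functional assay on A549 cells (Homo sapiens) for inhibition, read by sulforhodamine B assay, with a stated time of 48 h; a lower number here means a stronger inhibitor of growth, a higher number a weaker inhibitor of growth: compound 1 `COC(=O)[C@@]1(C)CCC=C2[C@@H]1CC[C@@H](C)[C@]2(C)Cc1c(C)n(C(c2ccccc2)c2ccccc2)c2ccc(Cl)cc12` and compound 2 `COC(=O)[C@@]1(C)CC[C@@H]2C3=C1CC[C@@H](C)[C@]3(C)C[C@@H]1c3ccccc3N[C@H]21`. Compound 1 sits at > 100000 nM, which is a limit of the assay and not a number (the limit of > 100000 nM in this assay, at which 1 of the 2 values shown sits). Among the compounds with values here, compound 2 gives 39000 nM, the only actual number in hand. Compound 3 `COC(=O)[C@@]1(C)CC[C@@H]2C3=C1CC[C@@H](C)[C@]3(C)C[C@@H]1c3cc(Br)ccc3N[C@H]21` differs from compound 2 by bromo in place of hydrogen on an aromatic carbon. Within the data shown here, no measured step of this kind exists here, so the step from compound 2 to compound 3 is expected to be small, a 1.6-fold lower number from compound 2 to compound 3 (0.19 log units; within the scatter), at most a modest move toward stronger inhibition. Compound 3 is estimated at 25000 nM, with a range from 8000 nM to 80000 nM.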

Compound 3, concentration for 50% growth inhibition: 40000 nM
Compound 3: the middle estimate sits 1.6-fold (0.20 log units) below what was measured; low and high end bracket the measured number.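

this assay now holds a one-place comparison on the shared core, with a 1.0-fold higher number from compound 2 to compound 3 (0.01 log units; within the scatter) for this change. A bromo on this aromatic carbon of the six-membered ring is therefore tolerated, but it brings no gain in growth inhibition beyond the scatter. Nothing in hand accounts for this flat step. Still open, going by these compounds, is whether a group other than bromo on this carbon, such as an amine or a carboxylic acid, would move the number. The same question stands for the other aromatic carbons of this ring.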